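Acylurea thiazole hydrazones: replacing dichlorophenyl with nitrophenyl

The compounds below may be only part of what the source reports. "The series", "measured", "known", "first", "only" and "open" are said of these compounds alone.

Three compounds of the series carry numbers in a functional assay on HepG2 cells (Homo sapiens) for inhibition, read by MTT assay, with a stated time of 72 h; on this read-out lower numbers stand for stronger inhibition and higher numbers for weaker inhibition. Compound 1 `CN(C(=O)NC(=O)c1ccc([N+](=O)[O-])cc1)c1nc(C(F)(F)F)c(C(=O)N/N=C/c2cccc(C(F)(F)F)c2)s1` gives 4.73 ug/mL in this assay. Compound 3 `CN(C(=O)NC(=O)c1ccc(Cl)c(Cl)c1)c1nc(C(F)(F)F)c(C(=O)N/N=C/c2ccc([N+](=O)[O-])cc2)s1` gives 6.85 ug/mL in this assay, and its number and that of compound 1 lie within the scatter of each other, so no order between the two can be read. Compound 2 `Cc1nc(N(C)C(=O)NC(=O)c2c(F)cccc2F)sc1C(=O)N/N=C/c1ccccc1F` returns only a limit in this assay, > 100 ug/mL, which is the limit of the read-out and not a number; it is recorded as the limit of > 100 ug/mL in this assay, at which 1 of the 3 values shown sits.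

Compound 4 `CN(C(=O)NC(=O)c1ccc([N+](=O)[O-])cc1)c1nc(C(F)(F)F)c(C(=O)N/N=C/c2ccc([N+](=O)[O-])cc2)s1` has not yet been measured in this assay. It differs from compound 3 in one place: 4-nitrophenyl in place of 3,4-dichlorophenyl on a carbonyl carbon. Among the measured compounds shown here, no pair of measured compounds differs in this one place, so no measured step covers the change. For the measured compounds named here, compound 1 already carries the 4-nitrophenyl on the carbonyl carbon and compound 3 carries the 4-nitrophenyl on the hydrazone side, and both give numbers close to each other in this assay, which is the only guide available.

On that basis the step from compound 3 to compound 4 is expected to be a 1.2-fold lower number from compound 3 to compound 4 (0.10 log units; within the scatter), nothing beyond the scatter in either direction. Compound 4 is therefore estimated at 5.5 ug/mL, within a range of 2 ug/mL to 18 ug/mL in this assay.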

Compound 4, half-maximal inhibitory concentration: 12.3 ug/mL
For compound 4 the middle estimate is 2.2-fold (0.35 log units) below the measured one, within the range that was stated.
By their numbers in this assay, from the lowest: compounds 1, 3 and 4 (each within the scatter of the next, the first and the last beyond it). At a limit, above all of these: compound 2.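

On the carbonyl carbon whose other neighbour is the amide-type nitrogen, 4-nitrophenyl in place of 3,4-dichlorophenyl gives a 1.8-fold higher number from compound 3 to compound 4 (0.25 log units; within the scatter), so in this assay this exchange gives no difference that can be read, and with the other groups of compound 3 kept, the position accepts either aryl group without a separable shift in the number. With 4-nitrophenyl kept on that carbonyl carbon, 4-nitrophenyl in place of 3-(trifluoromethyl)phenyl on a carbon with a double bond to nitrogen gives a 2.6-fold higher number from compound 1 to compound 4 (0.42 log units; beyond the scatter), a modest step and the only one of the two that can be read as a difference, which points to the carbon with a double bond to nitrogen as the more sensitive of the two places in this small set. Nothing in the data shown bears on why either step has the size it has.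

From the compounds shown here alone, whether the carbonyl-carbon exchange would read the same with 3-(trifluoromethyl)phenyl kept on the carbon with a double bond to nitrogen remains open. Also open, going by these compounds, is how either place would respond to an aryl group carrying an amine or a carboxylic acid, or to a longer alkyl chain in place of the aryl ring.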